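The source may report more compounds than this note shows. Statements on the series, on what has been measured and on what is new or still open speak of the compounds shown alone.

Measured in a functional assay on the whole organism (Myocardium) with Canis familiaris (Canis lupus familiaris) as the target, at a dose of 8.75 mg/kg by the intravenous route; on this read-out higher numbers stand for an effect only at larger amounts of compound and lower numbers for an effect already at smaller amounts:
Compound 1 `COc1cc2nc(O)nc(C)c2cc1OC`: 2.42 mg/kg
Compound 2 `COc1cc2nc(O)nc(C3CCCC3)c2cc1OC`: > 8.75 mg/kg

Compound 2 has no number on this read-out, only a limit: it stands at the limit of > 8.75 mg/kg in this assay, at which 1 of the 2 values shown sits. Compound 3 `COc1cc2nc(O)nc(C(F)(F)F)c2cc1OC` keeps the shared core and carries trifluoromethyl in place of cyclopentyl on an aromatic carbon, next to the ring nitrogen (trifluoromethyl in place of cyclopentyl on an aromatic carbon). For the measured compounds named here, only one measured step bears on this place: an at least 3.6-fold higher number from compound 1 to compound 2 (0.55 log units; beyond the scatter), where cyclopentyl replaced methyl. Compound 3 gives up that cyclopentyl, so part of this step is expected to be undone, back toward compound 1 at 2.42 mg/kg. Going by the values given here, no measurement yet shows how trifluoromethyl compares with methyl here, so the size stays uncertain. In this assay a move to a lower number is expected: an at least 1.9-fold lower number from compound 2 to compound 3 (0.28 log units; that floor lies within the scatter). For compound 3 the estimate is 4.5 mg/kg, with an expected range from 1.8 mg/kg to 11 mg/kg.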

Compound 3, dose for half-maximal effect: > 8.75 mg/kg
Compound 3 ended at the assay's limit (the forecaster's own chance of this, stated with the estimate: 30%); middle value at least 1.9-fold (0.28 log units) away from the limit.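

With methyl at this place, compound 1 is the only one of the three that gives a number in this assay, and trifluoromethyl in its place gives an at least 3.6-fold higher number from compound 1 to compound 3 (0.55 log units; beyond the scatter). The earlier compounds shown here showed this only for cyclopentyl, so the shift away from methyl does not depend on a ring in the group, as trifluoromethyl has none. Compound 2 and compound 3 both stand at a limit, so the step between them cannot be read, and neither can any order of the two: the limit of > 8.75 mg/kg in this assay, at which 2 of the 3 values shown sit.

On these data alone, how far compound 2 and compound 3 lie beyond that limit remains open. Also open, as far as these compounds go, is whether a group such as ethyl, an amine or plain hydrogen at this place would keep a readable number, or give a lower one than methyl.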